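This account rests on a few compounds, and the source may have more. Where it says the series, first, only, none or still open, it means among the compounds named here.

Two compounds of this series have a number in a functional assay on SK-N-SH cells (Homo sapiens) for cytotoxicity, read by MTT assay, with a stated time of 48 h (a higher number here means a weaker inhibitor, a lower number a stronger inhibitor), so far. Compound 1 `O=C1Nc2ccccc2C1(c1c[nH]c2ccc([N+](=O)[O-])cc12)c1c[nH]c2ccc([N+](=O)[O-])cc12` carries two nitro-substituted indole rings on the shared core and gives 11800 nM in this assay. Compound 2 `O=C1Nc2ccc(F)cc2C1(c1c[nH]c2ccc(Cl)cc12)c1c[nH]c2ccc(Cl)cc12` carries chloro on both indole rings and fluoro on the core and gives 8500 nM in this assay. Among the measured compounds shown here, the gap between compound 1 and compound 2 is within the scatter, so the two numbers cannot be placed in order; compound 1 is neither the weaker nor the stronger of the pair on these data, and no measured step between single changes is available.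

Compound 3 `O=C1Nc2ccc(F)cc2C1(c1c[nH]c2ccc([N+](=O)[O-])cc12)c1c[nH]c2ccc([N+](=O)[O-])cc12` keeps the two nitro-substituted indole rings of compound 1 and differs only by fluoro in place of hydrogen on an aromatic carbon. For the measured compounds named here, no single-change step of this kind has been measured, so the size of the move is open. Going by the values given here, the only comparison to hand, compound 2 against compound 1, mixes this change with a different indole substituent and still lands within the scatter. A step from compound 1 to compound 3 of no more than the scatter is therefore expected, in either direction, and the expected step is a 1.2-fold lower number from compound 1 to compound 3 (0.09 log units; within the scatter). Compound 3 is estimated at 9500 nM in this assay, with a range from 4000 nM to 25000 nM.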

Compound 3, half-maximal inhibitory concentration: 6800 nM
Compound 3: middle estimate off by 1.4-fold (0.15 log units), on the high side, and the stated range covers the measured number.
By their numbers in this assay, from the lowest: compounds 3, 2 and 1 (each within the scatter of the next).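

In this assay, among the compounds shown here, the first measured single change is fluoro in place of hydrogen on an aromatic carbon of the shared core, with both nitro-substituted indole rings kept, and it gives a 1.7-fold lower number from compound 1 to compound 3 (0.24 log units; within the scatter) in this comparison. The earlier compounds shown here could not separate this change from a change of indole substituent, whereas this pair isolates it at the position that is meta to a fused ring and para to a fused ring. On this one step, a single fluorine atom at that position leaves compound 1 and compound 3 unplaced in order, so the position accepts fluoro without a step beyond the scatter, and nothing measured here bears on the reason for that result.

As far as these compounds go, whether a larger or differently built group at the same position, such as methoxy, an amine or a carboxylic acid, would give a step beyond the scatter remains open. Also open, from the compounds shown here alone, is whether fluoro in place of hydrogen gives a similar step when the indole rings carry chloro, as in compound 2, rather than nitro.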